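Series notes: aryl exchange on the shared core

This account rests on a few compounds, and the source may have more. Where it says the series, first, only, none or still open, it means among the compounds named here.

Compound 1 `CC(=O)c1cccc(-c2ccc(C(=O)N(Cc3cccc(OCCCCCC(=O)O)c3)C(C)C)cc2)c1` and compound 2 `CC(C)N(Cc1cccc(OCCCCCC(=O)O)c1)C(=O)c1ccc(-c2ccoc2)cc1` share one core and differ only at a single aromatic carbon. In an ADME assay on HepG2 cells (Homo sapiens) for cytotoxicity, read by CellTiter-Glo and resazurin assay, with a stated time of 72 h (a higher number here means that more compound is needed for the effect, a lower number that less compound is needed), compound 1 gives > 26000 nM, which is a limit of the assay and not a number. In this assay compound 2 gives > 26000 nM, likewise a limit. The step that the two limits leave unreadable from compound 1 to compound 2 therefore cannot be read in size; the limit of > 26000 nM in this assay, at which 2 of the 2 values shown sit, is where both measured values sit. Compound 2 thus stands at the limit of this assay, with no measured number in the series to set beside it.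

Compound 3 `CC(C)N(Cc1cccc(OCCCCCC(=O)O)c1)C(=O)c1ccc(-c2ccc3c(c2)OCCO3)cc1` differs from compound 2 by 2,3-dihydro-1,4-benzodioxin-6-yl in place of furan-3-yl on an aromatic carbon. Going by the values given here, no readable measured step bears on this change, since the only step, a step that the two limits leave unreadable from compound 1 to compound 2, gives no size. Given that both measured compounds sit at the limit of this assay (the limit of > 26000 nM in this assay, at which 2 of the 2 values shown sit), compound 3 is expected to sit there as well, and the step that the limit leaves unreadable from compound 2 to compound 3 is expected to be none beyond the scatter. In this assay compound 3 is estimated at 40000 nM, within 15000 nM to 120000 nM, and most likely reported again only as a limit.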

Compound 3, half-maximal effective concentration: > 21900 nM
Compound 3 was reported as a limit (the forecaster's own chance of this, stated with the estimate: 85%); the middle value does not contradict the limit.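

In this assay compound 3 gives > 21900 nM, which is a limit of the assay and not a number. Going by these compounds alone, compound 1 and compound 2 also stand only as limits, so no step among compound 1, compound 2 and compound 3 can be read in size. The compounds shown leave open whether exchanging the group at this place on the shared core changes the half-maximal effective concentration at all.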